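The source may hold more compounds than are shown below. What is called first, only, known or untested is meant among the compounds shown, and "the series" means these compounds.

Working notes on the series, all read in a functional assay on MCF7 cells (Homo sapiens) for antiproliferative activity, read by WST assay, with a stated time of 3 days; a higher number here means a weaker inhibitor, a lower number a stronger inhibitor. Compound 1 `Nc1cc(=O)[nH]c(=O)n1[C@@H]1O[C@H](CO)[C@@H](O)[C@H]1O` gives > 50000 nM, and this is a limit of the assay rather than a number. Among the compounds with values here, compound 2 `[N-]=[N+]=Nc1c(F)c(=O)[nH]c(=O)n1[C@@H]1O[C@H](CO)[C@@H](O)[C@H]1O` gives 1000 nM, the only true number so far.

The next compound, compound 3 `Nc1c(F)c(=O)[nH]c(=O)n1[C@@H]1O[C@H](CO)[C@@H](O)[C@H]1O`, differs from compound 2 in one place: amino in place of azido on an aromatic carbon. This puts amino in place of azido on an aromatic carbon, ortho to a fluoro group.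

Within the data shown here, no measured step isolates this change, so the size of the effect in this assay remains an expectation. That expectation leans on compound 1, which also carries amino and whose value of > 50000 nM is a limit. A weakening clearly beyond the scatter is therefore expected, and the reading may itself end at a limit. The estimate implies an expected step of a 15-fold higher number from compound 2 to compound 3 (1.18 log units; beyond the scatter). The estimated value for compound 3 is 15000 nM, with an expected range of 3000 nM to 50000 nM.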

Compound 3, half-maximal inhibitory concentration: 1400 nM
The estimate for compound 3 lay 11-fold (1.03 log units) above the measured number; the measured number lies below the stated range.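

In this assay, amino in place of azido, ortho to a fluoro group, gives a 1.4-fold higher number from compound 2 to compound 3 (0.15 log units; within the scatter), so with the fluoro group present, the azido group is not needed for the activity of compound 2 and amino serves equally well at this position. Compound 1 therefore does not show that amino itself is poorly tolerated, as fluoro in place of hydrogen on the neighbouring aromatic carbon of the shared core gives an at least 35-fold lower number from compound 1 to compound 3 (1.55 log units; beyond the scatter), and with amino held constant the large change goes with the fluoro group. That step gives only a lower bound on the size of the change, since compound 1 sits at a limit and not at a number: the limit of > 50000 nM in this assay, at which 1 of the 3 values shown sits.

The compounds shown leave open how large the fluoro step truly is, and whether it would carry over to the azido compounds, where no pair with hydrogen in place of fluoro is available for comparison. From the compounds shown here alone, whether chloro or methyl in place of fluoro, or methylamino or hydroxyl in place of amino, would hold the reading also remains open.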